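Replacing the benzyl linker with a phenoxy linker

The source may report more compounds than this note shows. Statements on the series, on what has been measured and on what is new or still open speak of the compounds shown alone.

Compound 1 `Cc1ccccc1Cc1ccc(N2C[C@@H](C)C[C@H]2CC(=O)O)cc1`: 1100 nM in a functional assay on cells for agonist activity at Free fatty acid receptor 1 (Mus musculus), read by FLIPR and calcium flux, with a stated time of 100 s; on this read-out lower numbers stand for an effect already at smaller amounts and higher numbers for an effect only at larger amounts of compound
Compound 2 `Cc1ccccc1Cc1ccc(N2C[C@@H](C(F)(F)F)C[C@H]2CC(=O)O)cc1`: 710 nM in this assay
Compound 3 `Cc1ccccc1Cc1ccc(N2C[C@@H](c3ccccc3)C[C@H]2CC(=O)O)cc1`: > 33000 nM in this assay, which is a limit of the assay rather than a number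

Compound 2 holds the lowest of the two numbers, with compound 1 close by, since the step of a 1.5-fold lower number from compound 1 to compound 2 (0.19 log units; within the scatter) lies within the scatter. For compound 3 only a limit is known (the limit of > 33000 nM in this assay, at which 1 of the 3 values shown sits).

Compound 4 `Cc1cccc(C)c1Oc1ccc(N2C[C@@H](C(F)(F)F)C[C@H]2CC(=O)O)cc1` carries the change (2,6-dimethylphenoxy in place of 2-methylbenzyl on an aromatic carbon). All three measured steps concern the saturated ring carbon instead: a 1.5-fold lower number from compound 1 to compound 2 (0.19 log units; within the scatter) was small, while an at least 30-fold higher number from compound 1 to compound 3 (1.47 log units; beyond the scatter) and an at least 46-fold higher number from compound 2 to compound 3 (1.66 log units; beyond the scatter) were large. None touches the aromatic carbon, so the expected step is no more than the scatter: a 1.0-fold lower number from compound 2 to compound 4 (0.01 log units; within the scatter). Compound 4 is estimated at 700 nM, between 200 nM and 2500 nM.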

Compound 4, half-maximal effective concentration: 270 nM
Estimate against measurement, compound 4: 2.6-fold (0.41 log units) above; the range from low to high includes it.
By their numbers in this assay, from the lowest: compound 4; then compounds 2 and 1 (each within the scatter of the next). At a limit, above all of these: compound 3.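

Among these compounds, the step of a 2.6-fold lower number from compound 2 to compound 4 (0.42 log units; beyond the scatter) in this assay shows that the number responds to a change on the aromatic carbon, whereas the earlier compounds varied only the saturated ring carbon. The step is modest, and it changes the linker and the methyl pattern together, since 2,6-dimethylphenoxy replaces 2-methylbenzyl as a whole. Nothing available explains why the number falls.

Whether the oxygen or the second methyl accounts for the step remains open. So does how a 2-methylphenoxy group or an amine linker would read here.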